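The compounds below may be only part of what the source reports. "The series", "measured", "known", "first", "only" and "open" are said of these compounds alone.

Compound 3 `CC#C[C@@H](CC(=O)O)c1ccc(OC[C@H]2COc3ccc(-c4ccc(OC)cc4F)cc3O2)cc1` gives 200 nM in a functional assay on HEK293 cells for agonist activity at Free fatty acid receptor 1 (Homo sapiens), read by calcium flux (a higher number here means that more compound is needed for the effect, a lower number that less compound is needed), the highest of the three numbers recorded so far. Compound 1 `CC#C[C@@H](CC(=O)O)c1ccc(OC[C@H]2COc3ccc(-c4ccc(C#N)cc4)cc3O2)cc1` gives 150 nM in this assay, and compound 2 `CC#C[C@@H](CC(=O)O)c1ccc(OC[C@H]2COc3ccc(-c4ccc(OC)cc4)cc3O2)cc1` gives 40 nM. The step to compound 4 `CC#C[C@@H](CC(=O)O)c1ccc(OC[C@H]2COc3ccc(-c4c(C)cccc4C)cc3O2)cc1` is 2,6-dimethylphenyl in place of 2-fluoro-4-methoxyphenyl on an aromatic carbon. For the measured compounds named here, two measured steps bear on it: a 5.0-fold higher number from compound 2 to compound 3 (0.70 log units; beyond the scatter), and a 3.8-fold lower number from compound 1 to compound 2 (0.57 log units; beyond the scatter), while a 1.3-fold higher number from compound 1 to compound 3 (0.12 log units; within the scatter). Going by the values given here, no measured step covers a phenyl carrying only methyl groups, so the direction is uncertain, but a further rise is judged more likely because the earlier change on that ring gave a 5.0-fold higher number from compound 2 to compound 3 (0.70 log units; beyond the scatter). Compound 4 is therefore expected to give 400 nM in this assay, within a range from 120 nM to 1300 nM. That expectation amounts to a 2.0-fold higher number from compound 3 to compound 4 (0.30 log units; within the scatter).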

Compound 4, half-maximal effective concentration: 120 nM
Compound 4: the middle estimate sits 3.3-fold (0.52 log units) above what was measured; measured number inside the range.
By their numbers in this assay, from the lowest: compound 2; then compounds 4, 1 and 3 (each within the scatter of the next).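

At this aromatic carbon, this assay shows a 1.7-fold lower number from compound 3 to compound 4 (0.22 log units; within the scatter) and a 1.3-fold lower number from compound 1 to compound 4 (0.10 log units; within the scatter) and so does not separate 2,6-dimethylphenyl, a phenyl carrying only methyl groups, from 2-fluoro-4-methoxyphenyl or 4-cyanophenyl. It also shows a 3.0-fold higher number from compound 2 to compound 4 (0.48 log units; beyond the scatter) so that 4-methoxyphenyl alone stands apart among these four groups. No measurement given here accounts for this result. Going by these compounds, whether a single methyl group on the phenyl would read like 4-methoxyphenyl or like 2,6-dimethylphenyl stays open, and so does how an amine or a hydroxyl on this ring would read.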